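The source may report more compounds than this note shows. Statements on the series, on what has been measured and on what is new or still open speak of the compounds shown alone.

Measured in a functional assay, read by spectrophotometry; on this read-out higher numbers stand for an effect only at larger amounts of compound and lower numbers for an effect already at smaller amounts:
- compound 1 `COc1ccc(-c2cc(=O)c3ccc(OCCCN4CCC(C)CC4)cc3o2)cc1`: 26.6 nM
- compound 2 `COc1ccc(-c2cc(=O)c3ccc(OCCCCCN4CCC(CCO)CC4)cc3o2)cc1`: 27.9 nM

Within the data shown here, compound 2 stands level with compound 1, the only other measured compound, within the scatter. Compound 3 `COc1ccc(-c2cc(=O)c3ccc(OCCCCCCCN4CCC(CCO)CC4)cc3o2)cc1` follows from compound 2 through (a group of 11 heavy atoms (9 carbon, 1 nitrogen, 1 oxygen; one six-membered non-aromatic ring with 1 hetero atom) in place of a group of 9 heavy atoms (7 carbon, 1 nitrogen, 1 oxygen; one six-membered non-aromatic ring with 1 hetero atom), on a saturated chain carbon, five bonds along the chain from an oxygen on an aromatic ring). The 4-(2-hydroxyethyl)piperidin-1-yl ring stays in the new group, and the chain carrying it grows. Among the measured compounds shown here, only one measured step bears on this: a 1.0-fold higher number from compound 1 to compound 2 (0.02 log units; within the scatter). That step also put a larger group in place of a smaller one on the same chain, though it changed the ring substituent as well, so it is thin evidence. On that single step, no shift beyond the scatter is expected in this assay, and no direction can be given. The expected step is a 1.1-fold higher number from compound 2 to compound 3 (0.03 log units; within the scatter). For compound 3 the estimate is 30 nM, with an estimated range of 10 nM to 90 nM.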

Compound 3, half-maximal effective concentration: 35.7 nM
Estimate against measurement, compound 3: 1.2-fold (0.08 log units) below, within the range that was stated.
By their numbers in this assay, from the lowest: compounds 1, 2 and 3 (each within the scatter of the next).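

In this assay, among these compounds, this is the first step in which the chain alone changes while the 4-(2-hydroxyethyl)piperidin-1-yl ring stays in place: a 1.3-fold higher number from compound 2 to compound 3 (0.11 log units; within the scatter). The earlier step from the shorter chain also altered the ring substituent, so it could not separate the two changes; here, at the saturated chain carbon five bonds along the chain from an oxygen on an aromatic ring, the group of 11 heavy atoms stands level with the group of 9 heavy atoms. No supporting measurement on hand offers an explanation for this result.

Still open, as far as these compounds go, is whether a longer chain carrying the same ring would also stay level with compound 3 on this read-out. Also open, from the compounds shown here alone, is how a carboxylic acid or an amine in place of the hydroxyl of the 2-hydroxyethyl group would behave on the chain of compound 3.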